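Chloro in place of hydrogen: one step seen in two cores

The compounds below may be only part of what the source reports. "The series", "measured", "known", "first", "only" and "open" are said of these compounds alone.

Compound 1 `N#Cc1c(-c2nnc(-c3nn(-c4ccccc4)c(-c4ccccc4)c3C#N)c3nn(-c4ccccc4)cc23)nn(-c2ccccc2)c1-c1ccccc1` and compound 2 `N#Cc1c(-c2nnc(-c3nn(-c4ccccc4)c(-c4ccccc4)c3C#N)c3nn(-c4ccc(Cl)cc4)cc23)nn(-c2ccccc2)c1-c1ccccc1` differ in a single change, (chloro in place of hydrogen on an aromatic carbon). In a functional assay on BT-549 cells (Homo sapiens) for inhibition, read by sulforhodamine B assay, with a stated time of 48 h (a higher number here means a weaker inhibitor of growth, a lower number a stronger inhibitor of growth), compound 1 gives 11800 nM and compound 2 gives 1020 nM, so a 12-fold lower number from compound 1 to compound 2 (1.06 log units; beyond the scatter). Compound 3 `N#Cc1c(-c2nnc(-c3ccccc3)c3nn(-c4ccccc4)cc23)nn(-c2ccccc2)c1-c1ccccc1` gives 21800 nM in this assay; the difference between the core of compound 3 and the core of compound 1 is not broken down here, and the values of compound 3 and compound 1 lie within the scatter of each other. Compound 4 `N#Cc1c(-c2nnc(-c3ccccc3)c3nn(-c4ccc(Cl)cc4)cc23)nn(-c2ccccc2)c1-c1ccccc1` carries the same change relative to compound 3, (chloro in place of hydrogen on an aromatic carbon), with the place described in the same words as for compound 2. Beside the earlier step, a step of similar size is expected here, an 11-fold lower number from compound 3 to compound 4 (1.04 log units; beyond the scatter), resting on that one prior pair alone. Compound 4 is accordingly estimated at 2000 nM, expected to fall between 600 nM and 7000 nM.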

Compound 4, concentration for 50% growth inhibition: 38800 nM
Beside the measured number, compound 4's estimate is 19-fold (1.29 log units) below it, outside the stated range (above it).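

In this assay, the change from phenyl to 4-chlorophenyl gives a 1.8-fold higher number from compound 3 to compound 4 (0.25 log units; within the scatter), so the large drop seen on the core of compound 1 does not reappear on the core of compound 3. The two steps differ clearly: the same change on two cores in this assay, a 12-fold lower number (1.06 log units; beyond the scatter) from compound 1 to compound 2 and a 1.8-fold higher number (0.25 log units; within the scatter) from compound 3 to compound 4, 21-fold (1.31 log units) apart, beyond the scatter of two such steps

In these two pairs, the outcome of the change therefore depends on the core, and a step measured on one core is not a safe guide to the other; what in the cores produces the difference is not shown, and two pairs set no rule for further cores.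

The compounds shown carry only chloro as a replacement for this hydrogen. On these data alone, whether fluoro, methoxy or an amine at the same place would follow the step on the core of compound 1 or that on the core of compound 3 remains open.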